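The compounds below may be only part of what the source reports. "The series", "measured", "known", "first", "only" and "open" are said of these compounds alone.

Compound 1 `CC(C)(C)OC(=O)N1C[C@@H](n2cc(-c3ccc4nc(N)sc4n3)nn2)C[C@H]1C(=O)Nc1ccc(F)c(F)c1`: 26400 nM
Compound 2 `Nc1nc2ccc(-c3cn([C@@H]4CN[C@H](C(=O)Nc5ccc(Cl)c(C(F)(F)F)c5)C4)nn3)nc2s1`: 26200 nM
Compound 3 `Nc1nc2ccc(-c3cn([C@@H]4CN[C@H](C(=O)Nc5ccc(Br)cc5)C4)nn3)nc2s1`: 24400 nM

All three values come from a functional assay on K562 cells (Homo sapiens) for inhibition, read by MTT assay, with a stated time of 48 h; on this read-out higher numbers stand for weaker inhibition and lower numbers for stronger inhibition. Among the compounds with values here, compound 3 stands at 24400 nM, within the scatter of both compound 1 and compound 2, so the series shows no separation on these numbers so far.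

The next compound is compound 4 `Nc1nc2ccc(-c3cn([C@@H]4CN[C@H](C(=O)Nc5ccc(F)c(F)c5)C4)nn3)nc2s1`. The change is 3,4-difluorophenyl in place of 4-bromophenyl on an amide-type nitrogen.

Within the data shown here, one measured step bears on this directly. It is a 1.1-fold lower number from compound 2 to compound 3 (0.03 log units; within the scatter), which also exchanges the group on the amide-type nitrogen and stays within the scatter. A single step is thin evidence, but it gives no reason to look for a real shift, so with a 1.1-fold lower number from compound 2 to compound 3 (0.03 log units; within the scatter) as the guide no change beyond the scatter is expected in this assay, in either direction.

The expected step is a 1.0-fold lower number from compound 3 to compound 4 (0.01 log units; within the scatter). Compound 4 is estimated at 24000 nM, with an expected range of 12000 nM to 45000 nM.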

Compound 4, half-maximal inhibitory concentration: 33200 nM
Beside the measured number, compound 4's estimate is 1.4-fold (0.14 log units) below it; measured number inside the range.
By their numbers in this assay, from the lowest: compounds 3, 2, 1 and 4 (each within the scatter of the next).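

In this assay, the amide-type nitrogen now carries three different aryl groups without any separation: 3,4-difluorophenyl in place of 4-bromophenyl gives (a 1.4-fold higher number from compound 3 to compound 4 (0.13 log units; within the scatter)), and 3,4-difluorophenyl in place of 4-chloro-3-(trifluoromethyl)phenyl gives (a 1.3-fold higher number from compound 2 to compound 4 (0.10 log units; within the scatter)). Compound 4 also adds a second site to the comparison, since hydrogen in place of tert-butoxycarbonyl on an amine nitrogen in a ring gives (a 1.3-fold higher number from compound 1 to compound 4 (0.10 log units; within the scatter)), so with 3,4-difluorophenyl held constant that exchange also stays within the scatter. No measurement at hand accounts for these readings.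

A phenyl bearing a carboxylic acid or an amine, or a longer alkyl chain on the amide-type nitrogen, would test whether this position can move the number at all. Going by these compounds, whether an acetyl group on the ring amine nitrogen would read like hydrogen and tert-butoxycarbonyl also remains open.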